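The source may report more compounds than this note shows. Statements on the series, on what has been measured and on what is new or still open speak of the compounds shown alone.

Among the measured compounds shown here, compound 1 `CCCCN(CC)c1nc(C)nc2c(-c3ccc(OC)nc3C)c(C)nn12` gives 4.9 nM in an assay on cell membranes for displacement of a labelled ligand from corticotropin-releasing factor receptor 1 (Rattus norvegicus) (on this read-out higher numbers stand for weaker inhibition and lower numbers for stronger inhibition), the lower of the two numbers so far. Compound 2 `CCCN(CCC)c1nc(C)nc2c(-c3c(C)cc(N(C)C)nc3C)c(C)nn12` gives 14.9 nM in this assay, a higher number than compound 1 by a margin beyond the scatter; the two differ in several places, so no single step can be read from them. Compound 3 `CCCCN(C)c1nc(C)nc2c(-c3ccc(OC)nc3C)c(C)nn12` matches compound 1 except for (hydrogen in place of methyl on a saturated chain carbon bound to a nitrogen on an aromatic ring). With the shorter chain on the amino nitrogen, the step from compound 1 to compound 3 is expected to be a 1.6-fold higher number from compound 1 to compound 3 (0.21 log units; within the scatter), a slight weakening that may stay within the scatter. Compound 3 is therefore expected to give 8 nM, within 3 nM to 25 nM.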

Compound 3, half-maximal inhibitory concentration: 8.1 nM
Beside the measured number, compound 3's estimate is 1.0-fold (0.01 log units) below it; the measured number falls inside the stated range.
By their numbers in this assay, from the lowest: compounds 1, 3 and 2 (each within the scatter of the next, the first and the last beyond it).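

Among the compounds shown here, replacing butyl(ethyl)amino with butyl(methyl)amino gives the first single-place step, read in this assay (a 1.7-fold higher number from compound 1 to compound 3 (0.22 log units; within the scatter)). At this position, ethyl to methyl therefore leaves the two compounds within the scatter of each other, so this read-out does not separate the two chains. No measurement at hand bears on this step.

From the compounds shown here alone, a longer chain, such as propyl or butyl, in place of the ethyl remains open, as does a cyclopropylmethyl group. Also open, going by these compounds, is whether ethyl to methyl reads the same on the core of compound 2.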